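Removing the Methoxy from a Benzamide at the Binding Limit

The source may report more compounds than this note shows. Statements on the series, on what has been measured and on what is new or still open speak of the compounds shown alone.

Compound 2 `COc1ccc(C(=O)Nc2nc(-c3ccc(OC)cc3)nc3cn(-c4ccccc4)nc23)cc1` belongs to a small set of amide-bearing analogues built on one shared core. In an assay on HEK293 cells for displacement of a labelled ligand from adenosine receptor A3 (Rattus norvegicus), read by scintillation counting, with a stated time of 60 min (a lower number here means a stronger inhibitor, a higher number a weaker inhibitor), compound 2 gives only a limit, > 10000 nM, and not a number. Its neighbour compound 1 `COc1ccc(-c2nc(NC(=O)c3ccncc3)c3nn(-c4ccccc4)cc3n2)cc1` likewise gives only a limit in this assay, > 10000 nM. Within the data shown here, the step that the two limits leave unreadable from compound 1 to compound 2 therefore cannot be read, and the limit of > 10000 nM in this assay, at which 2 of the 2 values shown sit, shows that every value so far rests at that limit. Compound 3 `COc1ccc(-c2nc(NC(=O)c3ccccc3)c3nn(-c4ccccc4)cc3n2)cc1` differs from compound 2 by hydrogen in place of methoxy on an aromatic carbon. Among the measured compounds shown here, no measured step reports how the loss of a methoxy from this amide moves binding, and the single step between measured compounds is unreadable. The expectation for compound 3 is therefore that it stays near the same limit, with the step that the limit leaves unreadable from compound 2 to compound 3 expected to be small. Compound 3 is estimated at 15000 nM, within a range of 3000 nM to 60000 nM.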

Compound 3, inhibition constant: > 10000 nM
Compound 3: a limit, no number (the forecaster's own chance of this, stated with the estimate: 75%); the middle value lies beyond the limit too.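

Compound 3 also gives only a limit in this assay, > 10000 nM, so the steps to it from compound 1 and from compound 2 cannot be read. The compounds shown leave open how the group on the amide carbonyl moves binding, with every value resting at one point: the limit of > 10000 nM in this assay, at which 3 of the 3 values shown sit.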